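This account rests on a few compounds, and the source may have more. Where it says the series, first, only, none or still open, it means among the compounds named here.

The series is followed in an assay on membranes from HEK293 cells for displacement of a labelled ligand from D(4) dopamine receptor (Homo sapiens), read by scintillation counting, with a stated time of 60 min; a lower number here means a stronger inhibitor, a higher number a weaker inhibitor. Among the compounds with values here, compound 1, `[O-][S+](CCNC1CCN(Cc2ccc(F)cc2)CC1)C(c1ccc(F)cc1)c1ccc(F)cc1`, is the only member with a number: in this assay compound 1 gives 76800 nM, a weak result. Compound 2, `[O-][S+](CCNC1CCN(CC(O)Cc2ccccc2)CC1)C(c1ccc(F)cc1)c1ccc(F)cc1`, was entered in this assay, but in this assay compound 2 gives "not determined" (no result reported), so compound 2 stands nowhere on the numbers shown, and no step from compound 1 to compound 2 can be drawn. Compound 3, `O=C(c1ccc(F)cc1)N1CCC(NCC[S+]([O-])C(c2ccc(F)cc2)c2ccc(F)cc2)CC1`, is not yet measured. It differs from compound 2 by (4-fluorophenyl)carbonyl in place of 2-hydroxy-3-phenylpropyl on an amine nitrogen in a ring. Within the data shown here, since no measured step frames this change, the size of its effect in this assay cannot be read from the data; the only anchor is the weak number of compound 1, which shares the core. On that anchor alone, compound 3 is expected to give about 40000 nM in this assay, within a wide range from 4000 nM to 400000 nM.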

Compound 3, inhibition constant: > 100000 nM
Compound 3: no number, only a limit; the forecaster's own chance of this, stated with the estimate: 30%; at least 2.5-fold (0.39 log units) between middle value and limit.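

For compound 3 the result in this assay is only a limit, > 100000 nM, not a number. Within the data shown here, the one step that can be read is a floor, an at least 1.3-fold higher number from compound 1 to compound 3 (0.11 log units; that floor lies within the scatter), for (4-fluorophenyl)carbonyl in place of 4-fluorobenzyl on an amine nitrogen in a ring, so this change yields no stronger inhibitor at this position. That reading rests on a single limit: the limit of > 100000 nM in this assay, at which 1 of the 3 values shown sits.

From the compounds shown here alone, the step from compound 2 to compound 3 cannot be read, and how far compound 3 really lies from compound 1 stays unknown. Also open, going by these compounds, is whether any other group on this ring nitrogen, such as a longer alkyl chain or a sulfonyl group, would give a much lower number on the shared core.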